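A few compounds are considered here, and "the series" means these few. Any claim that something is new, unique, unknown or untested is made for them only; others in the source may bear on it.

Compound 1 `Cc1cc(C(=O)O)nn1C(C)c1cc(Cl)ccc1OCc1ccccc1`, compound 2 `Cc1cc(C(=O)NCc2ccccn2)nn1Cc1cc(Cl)ccc1OCc1ccccc1` and compound 3 `Cc1cc(C(=O)NN2CCCCC2)nn1Cc1cc(Cl)ccc1OCC(C)C` share one core and were measured in a physicochemical assay for lipophilicity, at pH 7.4; a lower number here means a more polar compound, a higher number a more lipophilic compound. Compound 1 gives 1 and compound 3 gives 3.3. For compound 2 only a limit of the method is known, > 3.7, and it stands at the limit of > 3.7 in this assay, at which 1 of the 3 values shown sits. Compound 4 `Cc1cc(NC(=O)c2c(F)cccc2F)nn1Cc1cc(Cl)ccc1OCc1ccccc1` has not yet been measured. It differs from compound 2 in one place: ((2,6-difluorophenyl)carbonyl)amino in place of ((pyridin-2-yl)methyl)carbamoyl on an aromatic carbon. Among the compounds with values here, no step between two measured compounds is known, so the size of this change cannot be read from the data. The step that the limit leaves unreadable from compound 2 to compound 4 is expected to be small, within the usual scatter. Compound 4 is expected to give 4, with a range from 3.4 to 4.6.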

Compound 4, distribution coefficient: > 3.7
Compound 4 ended at the assay's limit; the forecaster's own chance of this, stated with the estimate: 60%; the middle value lies beyond the limit too.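

Within the data shown here, compound 2 and compound 4 both end at a limit of this assay, so no step between them can be read: the limit of > 3.7 in this assay, at which 2 of the 4 values shown sit. Still open, on these data alone, is how large the change from ((pyridin-2-yl)methyl)carbamoyl to ((2,6-difluorophenyl)carbonyl)amino is, and in which direction it goes.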